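Turning the Double Bond of Compound 2 from E to Z

A few compounds are considered here, and "the series" means these few. Any claim that something is new, unique, unknown or untested is made for them only; others in the source may bear on it.

Of the compounds shown here, two have been measured in an assay on U2OS cells for activation of nuclear factor erythroid 2-related factor 2 (Homo sapiens), read by beta-arrestin recruitment, with a stated time of 6 h; on this read-out higher numbers stand for an effect only at larger amounts of compound and lower numbers for an effect already at smaller amounts. Compound 1 `O=S(=O)(/C=C\c1ncccc1F)c1ccccc1F` gives 482 nM, and compound 2 `O=S(=O)(/C=C/c1ncccc1F)c1ccccc1Cl` gives 122 nM, the lower of the two numbers, with compound 1 sitting beyond the scatter above it. Among the measured compounds shown here, no measured pair differs in only one place. Compound 3 `O=S(=O)(/C=C\c1ncccc1F)c1ccccc1Cl` follows from compound 2 by the two compounds have the same atoms and bonds and differ only in configuration as drawn: 1 of 1 stereo elements differ; a double bond is drawn E in compound 2 and Z in compound 3. The step from compound 2 to compound 3 is expected to run toward a higher number, likely beyond the scatter, because compound 1 gives 482 nM with its double bond also drawn Z. Compound 3 is therefore estimated at 350 nM, within 120 nM to 1200 nM. The expected step is a 2.9-fold higher number from compound 2 to compound 3 (0.46 log units; beyond the scatter).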

Compound 3, half-maximal effective concentration: 583 nM
Estimate against measurement, compound 3: 1.7-fold (0.22 log units) below; the range from low to high includes it.
By their numbers in this assay, from the lowest: compound 2; then compounds 1 and 3 (each within the scatter of the next).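

The first comparison in this assay that turns on this double bond alone gives a 4.8-fold higher number from compound 2 to compound 3 (0.68 log units; beyond the scatter), so with the chloro group in place, the Z form reads higher than the E form, and the shift can be set on configuration: the fact that compounds 2 and 3 differ only in the configuration as drawn

With the double bond drawn Z, chloro in place of fluoro on an aromatic carbon gives a 1.2-fold higher number from compound 1 to compound 3 (0.08 log units; within the scatter), so this exchange does not separate the two Z compounds.

Still open, going by these compounds, is whether the configuration would count the same with a methoxy group or a nitrile in place of the halogen.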